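The source may report more compounds than this note shows. Statements on the series, on what has been measured and on what is new or still open speak of the compounds shown alone.

Working notes on the series. Compound 1 `CCC(=O)N1C[C@H](NC(=O)c2ccc(-n3ccccc3=O)cc2)[C@H](NC(=O)c2ccc(Cl)s2)C1`, compound 2 `O=C(N[C@H]1CN(C(=O)C2CC2)C[C@H]1NC(=O)c1ccc(Cl)s1)c1ccc(-n2ccccc2=O)cc1` and compound 3 `COCCOC(=O)N1C[C@H](NC(=O)c2ccc(-n3ccccc3=O)cc2)[C@H](NC(=O)c2ccc(Cl)s2)C1` share one core and differ in the group on a carbonyl carbon. In an ADME assay on HEK293 cells (Homo sapiens) for cytotoxicity (a lower number here means a stronger inhibitor, a higher number a weaker inhibitor), compound 1 gives > 100000 nM, which is a limit of the assay. Compound 2 gives > 100000 nM, again a limit. Compound 3 gives > 100000 nM, also a limit and not a number. All three therefore stand together at the limit of > 100000 nM in this assay, at which 3 of the 3 values shown sit.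

Next comes compound 4 `O=C(N[C@H]1CN(C(=O)N2CCCC2)C[C@H]1NC(=O)c1ccc(Cl)s1)c1ccc(-n2ccccc2=O)cc1`, with pyrrolidin-1-yl in place of 2-methoxyethoxy on a carbonyl carbon.

The measured changes at this place are a step that the two limits leave unreadable from compound 1 to compound 2, a step that the two limits leave unreadable from compound 1 to compound 3 and a step that the two limits leave unreadable from compound 2 to compound 3. None has a readable size, and none of the three compounds gives a number in this assay. No step beyond the scatter is therefore expected, in either direction. The expected change is a number no higher from compound 3 to compound 4 (the limit leaves the size open). For compound 4 the estimate is 100000 nM, with an expected range from 40000 nM to 150000 nM.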

Compound 4, half-maximal inhibitory concentration: > 100000 nM
Compound 4: a limit, no number; the forecaster's own chance of this, stated with the estimate: 90%; the middle value lies on the limit itself.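

No new step can be read for compound 4: its comparisons with compound 1, compound 2 and compound 3 each join two limits, so none has a readable size. The compounds shown leave open how far any of the four lies beyond the limit in this assay. All four stand together: the limit of > 100000 nM in this assay, at which 4 of the 4 values shown sit.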